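Compound 3 and the limit set by compound 2

The source may report more compounds than this note shows. Statements on the series, on what has been measured and on what is new or still open speak of the compounds shown alone.

In a functional assay (aorta) with Rattus norvegicus as the target; a lower number here means that less compound is needed, a higher number that more compound is needed for the effect:
Compound 1 `COc1ccc(-c2nc(CNC(=O)N3CCOCC3)sc2-c2ccc(OC)cc2)cc1`: 12 uM
Compound 2 `CCOC(=O)/C(C#N)=C/c1nc(-c2ccc(OC)cc2)c(-c2ccc(OC)cc2)s1`: > 100 uM, a limit

Compound 2 stands at > 100 uM, which is a limit and not a number. Compound 3 `COc1ccc(-c2nc(/C=C/C(=O)O)sc2-c2ccc(OC)cc2)cc1` carries 2-carboxyethenyl in place of 2-cyano-2-(ethoxycarbonyl)ethenyl on an aromatic carbon. Going by the values given here, only one measured step bears on this place, an at least 8.3-fold higher number from compound 1 to compound 2 (0.92 log units; beyond the scatter), and it lies beyond the scatter. Compound 1, at 12 uM, shows that a lower number is possible with another group there, so a modest move to a lower number is expected in this assay. The expected step is an at least 2.2-fold lower number from compound 2 to compound 3 (0.34 log units; beyond the scatter). For compound 3 the estimate is 45 uM, with an expected range of 12 uM to 150 uM.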

Compound 3, concentration for half-maximal effect: 55 uM
Estimate against measurement, compound 3: 1.2-fold (0.09 log units) below; measured number inside the range.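

In this assay, 2-carboxyethenyl in place of 2-cyano-2-(ethoxycarbonyl)ethenyl on this aromatic carbon gives an at least 1.8-fold lower number from compound 2 to compound 3 (0.25 log units; that floor lies within the scatter). From the compounds shown here alone, compound 2 has a limit and not a number, so the true size of this step stays unknown: the limit of > 100 uM in this assay, at which 1 of the 3 values shown sits. Of the three groups, (((morpholin-4-yl)carbonyl)amino)methyl still gives the lowest number, with a 4.6-fold higher number from compound 1 to compound 3 (0.66 log units; beyond the scatter).

The compounds shown leave open whether the carboxylic acid or the double bond matters here. A saturated 2-carboxyethyl chain, or a 2-(ethoxycarbonyl)ethenyl group without the nitrile, would help separate these parts.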